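Swapping Trifluoromethyl for Methoxy on a Shared Core

A few compounds are considered here, and "the series" means these few. Any claim that something is new, unique, unknown or untested is made for them only; others in the source may bear on it.

Of the compounds shown here, three have so far been measured in a functional assay on MCF7 cells (Homo sapiens) for antiproliferative activity, read by MTT assay, with a stated time of 24 h; on this read-out lower numbers stand for stronger inhibition and higher numbers for weaker inhibition. Compound 1 `FC(F)(F)c1ccc(C2CC(c3ccccc3)=NN2c2ccc(-c3ccccc3)nn2)cc1` gives 100000 nM in this assay. Compound 2 `COc1ccc(C2CC(c3ccccc3)=NN2c2ccc(-c3ccccc3)nn2)cc1` differs from compound 1 by methoxy in place of trifluoromethyl on an aromatic carbon; in this assay compound 2 gives 100000 nM, and the step is no change at the digits printed from compound 1 to compound 2 (within the scatter). Compound 3 `COc1ccc(C2=NN(c3ccc(-c4ccccc4)nn3)C(c3ccc(C(F)(F)F)cc3)C2)cc1` differs from compound 1 by methoxy in place of hydrogen on an aromatic carbon; in this assay compound 3 gives 46800 nM, which amounts to a 2.1-fold lower number from compound 1 to compound 3 (0.33 log units; beyond the scatter). Compound 3 therefore carries the lowest number of the three, with its steps to compound 1 and to compound 2 both beyond the scatter.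

Compound 4 `COc1ccc(C2=NN(c3ccc(-c4ccccc4)nn3)C(c3ccc(OC)cc3)C2)cc1` has not yet been measured. It differs from compound 3 by methoxy in place of trifluoromethyl on an aromatic carbon. This is the same change that was made from compound 1 to compound 2, and there it produced no change at the digits printed from compound 1 to compound 2 (within the scatter). For the measured compounds named here, the only precedent for this change thus left the number where it was, and both compounds of that precedent sit at the high end of the measured range, so the precedent is thin.

Resting on that single earlier step, compound 4 is expected to stay close to compound 3, with an expected step of a 1.0-fold lower number from compound 3 to compound 4 (0.02 log units; within the scatter). The estimate for compound 4 in this assay is 45000 nM, expected to fall between 18000 nM and 100000 nM.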

Compound 4, half-maximal inhibitory concentration: 100000 nM
For compound 4 the middle estimate is 2.2-fold (0.35 log units) below the measured one, within the range that was stated.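

In this assay, methoxy in place of trifluoromethyl gives a 2.1-fold higher number from compound 3 to compound 4 (0.33 log units; beyond the scatter), yet the step on this core cannot be told apart from the earlier one: the same change on two cores in this assay, no change at the digits printed (within the scatter) from compound 1 to compound 2 and a 2.1-fold higher number (0.33 log units; beyond the scatter) from compound 3 to compound 4, 2.1-fold (0.33 log units) apart, within the scatter of two such steps. Methoxy in place of hydrogen on an aromatic carbon gives no change at the digits printed from compound 2 to compound 4 (within the scatter), and this step likewise cannot be told apart from its counterpart on the other core: the same change on two cores in this assay, a 2.1-fold lower number (0.33 log units; beyond the scatter) from compound 1 to compound 3 and no change at the digits printed (within the scatter) from compound 2 to compound 4, 2.1-fold (0.33 log units) apart, within the scatter of two such steps. These comparisons show that neither change has a measurably different effect on the two cores, but they do not show that either change carries over at the same size, as each rests on one pair per core and each pair of steps combines one step beyond the scatter with one within it.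

The compounds shown leave open whether the same steps would appear with other groups at this place, such as an amine, a carboxylic acid or a longer alkoxy chain in place of methoxy. They also leave open whether the steps would hold on a further core, or in compounds giving much lower numbers than the four here.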